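Swapping Chloro for Methyl in a Urotensin Receptor Agonist Series

The compounds below may be only part of what the source reports. "The series", "measured", "known", "first", "only" and "open" are said of these compounds alone.

Three compounds have so far been measured in a functional assay on NIH3T3 cells for agonist activity at Urotensin-2 receptor (Homo sapiens), with a stated time of 5 days; on this read-out higher numbers stand for an effect only at larger amounts of compound and lower numbers for an effect already at smaller amounts:
compound 1, `COc1ccc(/C=C/C(=O)NC(CCN(C)C)c2ccc(C)cc2)cc1`, gives 2000 nM
compound 2, `COc1ccc(/C=C/C(=O)NC(CCN(C)C)c2ccc(Cl)cc2)cc1`, gives 513 nM
compound 3, `COc1ccc(CCC(=O)NC(CCN(C)C)c2ccc(Cl)cc2)cc1`, gives 2950 nM

Compound 2 and compound 1 share one core and differ by methyl in place of chloro on an aromatic carbon; that step reads a 3.9-fold higher number from compound 2 to compound 1 (0.59 log units; beyond the scatter). Compound 3 has a different core from compound 2, and the difference between the two cores is not broken down here. Compound 3 shows the highest of the three numbers, within the scatter of compound 1 but beyond it against compound 2.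

Compound 4, `COc1ccc(CCC(=O)NC(CCN(C)C)c2ccc(C)cc2)cc1`, is not yet measured. It differs from compound 3 by methyl in place of chloro on an aromatic carbon, the same change at the same place as from compound 2 to compound 1. For compound 4 the expected step is a 3.1-fold higher number from compound 3 to compound 4 (0.48 log units; beyond the scatter). That expectation rests on the earlier step, a 3.9-fold higher number from compound 2 to compound 1 (0.59 log units; beyond the scatter). Compound 4 is therefore estimated at 9000 nM, expected between 3000 nM and 30000 nM.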

Compound 4, half-maximal effective concentration: 5370 nM
The estimate for compound 4 lay 1.7-fold (0.22 log units) above the measured number; the measured number falls inside the stated range.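

In this assay, putting methyl in place of chloro on the core of compound 3 gives a 1.8-fold higher number from compound 3 to compound 4 (0.26 log units; within the scatter), a step that cannot be told apart from repeat-to-repeat variation when taken alone. Set beside the earlier step, it does not differ by more than two such steps normally would: the same change on two cores in this assay, a 3.9-fold higher number (0.59 log units; beyond the scatter) from compound 2 to compound 1 and a 1.8-fold higher number (0.26 log units; within the scatter) from compound 3 to compound 4, 2.1-fold (0.33 log units) apart, within the scatter of two such steps. The swap may therefore have a similar size on both cores, but two pairs cannot show that it does, nor that it would hold on any further core.

As far as these compounds go, only chloro and methyl appear at this place on the ring, so the outcome with bromo, methoxy or trifluoromethyl there remains open. Also open, from the compounds shown here alone, is how a longer chain between the amide and the dimethylamino group would read.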